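Swapping the Aryl Group on a Small-Molecule Receptor Agonist

A few compounds are considered here, and "the series" means these few. Any claim that something is new, unique, unknown or untested is made for them only; others in the source may bear on it.

Compound 1 `CC(C)OC(=O)N1CCC(Oc2ncnc3c2CCN3c2ccc(S(C)(=O)=O)cc2)CC1` is the weaker of two compounds tested in a functional assay on CHO-K1 cells for agonist activity at Glucose-dependent insulinotropic receptor (Homo sapiens), read by a luciferase reporter, with a stated time of 5 h (on this read-out higher numbers stand for an effect only at larger amounts of compound and lower numbers for an effect already at smaller amounts), giving 126 nM, while compound 2 `CC(C)(C)COC(=O)N1CCC(Oc2ncnc3c2CCN3c2ccc(S(C)(=O)=O)cc2F)CC1` gives 39.8 nM, a gap beyond the usual scatter. Compound 3 `Cc1ncccc1N1CCc2c(OC3CCN(C(=O)OC(C)C)CC3)ncnc21`, not yet measured, differs from compound 1 by 2-methylpyridin-3-yl in place of 4-(methylsulfonyl)phenyl on a nitrogen on an aromatic ring in a ring. Going by the values given here, no measured pair shows this change, so its effect is uncertain. Compound 3 is expected to be less potent than compound 1, with an estimated step of a 2.5-fold higher number from compound 1 to compound 3 (0.40 log units; beyond the scatter) in this assay. The value for compound 3 is expected near 320 nM, between 80 nM and 1500 nM.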

Compound 3, half-maximal effective concentration: > 10000 nM
Compound 3 ended at the assay's limit; the forecaster's own chance of this, stated with the estimate: 15%; at least 31-fold (1.49 log units) between middle value and limit.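

Both compounds measured earlier carry a 4-(methylsulfonyl)phenyl group on this ring nitrogen, so they gave no view of how much this place matters. Putting 2-methylpyridin-3-yl there gives an at least 79-fold higher number from compound 1 to compound 3 (1.89 log units; beyond the scatter), a large loss of potency. From the compounds shown here alone, compound 3 gives only a limit of the assay, not a number, and the full size of the step remains unknown: the limit of > 10000 nM in this assay, at which 1 of the 3 values shown sits.

The swap changes the ring, the methyl and the methylsulfonyl group together, and these compounds cannot separate their shares. A plain phenyl group or a 4-cyanophenyl group here remains an open case.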